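This account rests on a few compounds, and the source may have more. Where it says the series, first, only, none or still open, it means among the compounds named here.

In a functional assay on MCF7 cells (Homo sapiens) for antiproliferative activity, read by CCK-8 assay, with a stated time of 72 h (a higher number here means a weaker inhibitor, a lower number a stronger inhibitor), compound 1 `CCOc1cc(C(C)(C)C)ccc1C1=NC(c2ccc(Cl)cc2)C(c2ccc(Cl)cc2)N1C(=O)NCCCCCCC(=O)Nc1ccccc1N` gives > 100000 nM, which is a limit of the assay and not a number. For the measured compounds named here, compound 2 `CCOc1cc(C(C)(C)C)ccc1C1=NC(c2ccc(Cl)cc2)C(c2ccc(Cl)cc2)N1C(=O)N1CCN(Cc2ccc(C(=O)NO)cc2)CC1` gives 3970 nM, the only actual number so far. Compound 3 `CCOc1cc(C(C)(C)C)ccc1C1=NC(c2ccc(Cl)cc2)C(c2ccc(Cl)cc2)N1C(=O)N1CCN(CCCCCCCC(=O)NO)CC1` has 6-(hydroxycarbamoyl)hexyl in place of 4-(hydroxycarbamoyl)phenyl on a saturated chain carbon bound to an amine nitrogen in a ring. Going by the values given here, both groups end in hydroxycarbamoyl, and no measured pair tests this swap, so no shift beyond the usual scatter is expected in this assay. The expected change is a step of a 1.3-fold higher number from compound 2 to compound 3 (0.10 log units; within the scatter). For compound 3 the estimate is 5000 nM, with an expected range of 1500 nM to 20000 nM.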

Compound 3, half-maximal inhibitory concentration: 4830 nM
Compound 3: middle estimate off by 1.0-fold (0.02 log units), on the high side, within the range that was stated.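

In this assay, putting 6-(hydroxycarbamoyl)hexyl in place of 4-(hydroxycarbamoyl)phenyl gives a 1.2-fold higher number from compound 2 to compound 3 (0.09 log units; within the scatter). This is the only pair shown that differs in one place, and it shows that, at this position, a ringless chain and an aromatic ring carrying the same end group cannot be told apart in this measurement. Nothing in the data shown explains this result. Going by these compounds, it remains open whether a shorter or longer chain ending in hydroxycarbamoyl would read the same, and what a carboxylic acid in place of the hydroxycarbamoyl would give.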